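This account rests on a few compounds, and the source may have more. Where it says the series, first, only, none or still open, it means among the compounds named here.

Measured compounds:
compound 1, `COc1ccc2nc(SCC(=O)N(Cc3ccc(OC)c(O)c3)c3cc(OC)c(OC)c(OC)c3)sc2c1`, 71 nM
compound 2, `COc1ccc(CN(C(=O)CSc2nc3ccccc3s2)c2cc(OC)c(OC)c(OC)c2)cc1C`, 6360 nM

Within the data shown here, in a functional assay on MGC-803 cells (Homo sapiens) for antiproliferative activity, read by MTT assay, with a stated time of 48 h (on this read-out lower numbers stand for stronger inhibition and higher numbers for weaker inhibition), compound 2 stands at the highest of the two numbers; compound 1 gives a number far lower, a gap beyond the scatter, though the two compounds differ in more than one place and no single step joins them. Compound 3, `COc1ccc(CN(C(=O)CSc2nc3ccccc3s2)c2cc(OC)c(OC)c(OC)c2)cc1N`, differs from compound 2 by amino in place of methyl on an aromatic carbon. Among the measured compounds shown here, no measured pair shows this change, so its size is open. Compound 3 is expected to move to a lower number than compound 2 by a modest step, a 4.2-fold lower number from compound 2 to compound 3 (0.63 log units; beyond the scatter). The estimate for compound 3 is 1500 nM, ranging from 300 nM to 8000 nM.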

Compound 3, half-maximal inhibitory concentration: 84 nM
Compound 3: the middle estimate sits 18-fold (1.25 log units) above what was measured; measured number outside the range, below it.
By their numbers in this assay, from the lowest: compounds 1 and 3 (each within the scatter of the next); then compound 2.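

Replacing the 4-methoxy-3-methylbenzyl group with the 3-amino-4-methoxybenzyl group gives, in this assay, a 76-fold lower number from compound 2 to compound 3 (1.88 log units; beyond the scatter). This shows that the aromatic carbon ortho to a methoxy group is highly sensitive to what it carries, and that amino in place of methyl is a large change there, not a modest one. Nothing available explains why the step is this large. As far as these compounds go, it remains open whether the amino group itself is needed, or whether a hydroxyl, a methylamino or an acetamido group on the same carbon would give a similar number. Also open, from the compounds shown here alone, is how the amino group would fare on another carbon of that ring.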